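The compounds below may be only part of what the source reports. "The series", "measured", "known", "first", "only" and "open" are said of these compounds alone.

Measured so far in a functional assay on A549 cells (Homo sapiens) for cytotoxicity, read by MTT assay, with a stated time of 48 h (a lower number here means a stronger inhibitor, a higher number a weaker inhibitor), are two compounds
compound 1 `CC1(C)CCC[C@]2(C)[C@@H](CC[C@@](C)(O)/C=C/c3cccc([N+](=O)[O-])c3)[C@](C)(O)CC[C@@H]12` gives 3400 nM
compound 2 `CC1(C)CCC[C@]2(C)[C@@H](CC[C@@](C)(O)/C=C/c3ccc(Cl)nc3)[C@](C)(O)CC[C@@H]12` gives 3280 nM

Within the data shown here, compound 2 cannot be told apart from the only other measured compound: the step of a 1.0-fold lower number from compound 1 to compound 2 (0.02 log units; within the scatter) lies within the usual scatter, so neither counts as ahead. Compound 3 `CC1(C)CCC[C@]2(C)[C@@H](CC[C@@](C)(O)/C=C/c3ccc(Br)cc3)[C@](C)(O)CC[C@@H]12` keeps the shared core and changes one group (4-bromophenyl in place of 6-chloropyridin-3-yl on a double-bonded chain carbon bound to a double-bonded chain carbon). Among the measured compounds shown here, the change falls at the same place as the only measured step, and that step a 1.0-fold lower number from compound 1 to compound 2 (0.02 log units; within the scatter) stayed within the scatter even though a different ring came in there. For the measured compounds named here, one step is a thin basis, and no 4-bromophenyl compound has been measured yet, so what follows is a cautious expectation. In this assay no step beyond the scatter is expected, and the estimated step (a 1.1-fold lower number from compound 2 to compound 3 (0.04 log units; within the scatter)) reflects that. For compound 3 the expected value is 3000 nM with a range from 1300 nM to 7000 nM in this estimate.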

Compound 3, half-maximal inhibitory concentration: 43200 nM
The estimate for compound 3 lay 14-fold (1.16 log units) below the measured number; the whole stated range lies below it.
By their numbers in this assay, from the lowest: compounds 2 and 1 (each within the scatter of the next); then compound 3.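

This place on the double-bonded chain carbon is not indifferent to the ring it carries: in this assay, 4-bromophenyl gives a 13-fold higher number from compound 2 to compound 3 (1.12 log units; beyond the scatter), and the same group gives a 13-fold higher number from compound 1 to compound 3 (1.10 log units; beyond the scatter). The close match of compound 1 and compound 2 therefore did not mean that any aromatic ring is accepted here, since 4-bromophenyl has the same count of heavy atoms as the 6-chloropyridin-3-yl it replaces and still gives a much weaker result. No supporting measurement is available to say what lies behind this loss.

Compound 3 changes the ring atoms and the halogen together, so the compounds shown cannot separate the two; a 4-chlorophenyl group would bear on that. From the compounds shown here alone, how a ring carrying an amine or a carboxylic acid behaves at this place also remains open.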